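A few compounds are considered here, and "the series" means these few. Any claim that something is new, unique, unknown or untested is made for them only; others in the source may bear on it.

Three compounds share one core and differ only in where a hydroxy sits on a six-membered aromatic ring of carbon only. Compound 1 `Oc1ccccc1NC(=S)Nc1ccc2[nH]ccc2c1`, compound 2 `Oc1cccc(NC(=S)Nc2ccc3[nH]ccc3c2)c1` and compound 3 `Oc1ccc(NC(=S)Nc2ccc3[nH]ccc3c2)cc1` were all tested in an ADME assay on isolated protein for inhibition of peroxidase (Raphanus sativus), read by fluorescence and Amplex Red, tested at 5 uM; a lower number here means a stronger effect, a higher number a weaker effect of the compound at the concentration tested. In this assay compound 1 gives 43.9%, compound 2 gives 81.4% and compound 3 gives 41.5%. Compound 3 thus holds the lowest of the three numbers; compound 1 lies within the scatter of it, so the two cannot be ranked, while compound 2 stands beyond the scatter above it.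

Compound 4 `S=C(Nc1ccc(Br)cc1)Nc1ccc2[nH]ccc2c1` has not been measured. It differs from compound 3 in one place: bromo in place of hydroxy on an aromatic carbon. Within the data shown here, no measured pair shows this exchange, so the data give no direct size for the step. The only hint is that the hydroxy position alone carries compound 2 to 81.4%, beyond the scatter from compound 3, so the read-out does respond to this group. Compound 4 is estimated at 65%, with a range from 40% to 90%. The step from compound 3 to compound 4 is expected to be a number 23.5 percentage points higher from compound 3 to compound 4 (beyond the scatter), upward and beyond the scatter.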

Compound 4, a percentage reported as activity, at one concentration (the size of the read-out at that concentration, not a potency): 82%
Estimate against measurement, compound 4: 17 percentage points below; the range from low to high includes it.
By their numbers in this assay, from the lowest: compounds 3 and 1 (each within the scatter of the next); then compounds 2 and 4 (each within the scatter of the next).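

In this assay, among these compounds, the position para to a large group had so far been seen only through where the hydroxy sits, and compound 4 is the first case in which the group itself changes while its place stays the same. Bromo in place of hydroxy on this aromatic carbon gives a number 40.5 percentage points higher from compound 3 to compound 4 (beyond the scatter), a large step, which shows that the low number of compound 3 at 41.5% depends on which group occupies this place and not only on a substituent being present there. No measurement among those shown accounts for why this exchange carries such weight, so the size of the step stands here as an observation without an explanation.

With a single exchange at this place, the compounds shown leave open whether the high number belongs to bromo in particular or would also come with other groups, such as an amine, a methoxy group or a carboxylic acid. Among the compounds shown here, they also leave open how bromo would behave at the other places on this ring, where the hydroxy series has so far given the only readings.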